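Removing a methyl from a chloroacetamide side chain

This account rests on a few compounds, and the source may have more. Where it says the series, first, only, none or still open, it means among the compounds named here.

Of the compounds shown here, two have been tested in a functional assay on CCRF-CEM cells (Homo sapiens) for antiproliferative activity, read by MTT assay, with a stated time of 72 h; a lower number here means a stronger inhibitor, a higher number a weaker inhibitor. Compound 1, `Cc1cc(/C=C/C(=O)NC(N)=O)cc(NC(=O)C(C)Br)c1`, carries a bromopropanoyl amide on its ring and gives 4820 nM. Compound 2, `CNC(=O)NC(=O)c1cccc(NC(=O)C(C)Cl)c1`, carries a chloropropanoyl amide on a different core, and for compound 2 this assay reports only a limit of > 20000 nM, which is the edge of what this assay can measure and not a number. On these data alone, compound 2 therefore stands at the limit of > 20000 nM in this assay, at which 1 of the 2 values shown sits, so its true activity is unknown beyond being weak. Compound 3, `CNC(=O)NC(=O)c1cccc(NC(=O)CCl)c1`, differs from compound 2 by hydrogen in place of methyl on a saturated chain carbon bound to a carbonyl carbon and a chlorine atom. For the measured compounds named here, no measured pair shows the effect of this exact change, so there is no step to lean on. The expectation for compound 3 is a modest step from compound 2 of an at least 1.3-fold lower number from compound 2 to compound 3 (0.12 log units; that floor lies within the scatter), toward somewhat stronger inhibition, with a real chance that this assay again reports only a limit. On that basis compound 3 is estimated at 15000 nM, with a range from 4000 nM to 40000 nM.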

Compound 3, half-maximal inhibitory concentration: 9100 nM
The estimate for compound 3 lay 1.6-fold (0.22 log units) above the measured number, within the range that was stated.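

Taking the methyl off the saturated chain carbon bound to a carbonyl carbon and a chlorine atom, which turns 1-chloroethyl into chloromethyl, moves the series from a limit to a readable number in this assay: the change gives an at least 2.1-fold lower number from compound 2 to compound 3 (0.34 log units; beyond the scatter). On these data alone, the full size of this step stays unknown, since compound 2 is pinned down only by a limit of the assay: the limit of > 20000 nM in this assay, at which 1 of the 3 values shown sits. The methyl is therefore not needed for activity on this core, but this rests on one pair and says nothing about the core of compound 1, which differs from compound 3 in more than one place and so cannot be compared with it directly.

What the compounds shown leave open is how much of the activity depends on the chlorine itself, since no pair on this core sets chloromethyl against bromomethyl, or against a plain methyl with no halogen at all. Also open, as far as these compounds go, is whether a longer chain carrying the chlorine, or an amine in place of the chlorine, would keep the number reached by compound 3.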